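A few compounds are considered here, and "the series" means these few. Any claim that something is new, unique, unknown or untested is made for them only; others in the source may bear on it.

Measured compounds:
compound 1 `N#CCCn1nc(-c2ccc(OCc3ccccc3)cc2)oc1=O`: in an assay for inhibition of Amine oxidase [flavin-containing] B (Rattus norvegicus) (a higher number here means a weaker inhibitor, a lower number a stronger inhibitor), compound 1 gives 2.2 nM
compound 2 `N#CCCn1nc(-c2ccc(OCc3cccc(Cl)c3)cc2)oc1=O`: in this assay compound 2 gives 12 nM

For the measured compounds named here, compound 1 has the lowest of the two numbers; the only measured step, a 5.5-fold higher number from compound 1 to compound 2 (0.74 log units; beyond the scatter), is a change on the aromatic ring. Compound 3 `CC(C#N)Cn1nc(-c2ccc(OCc3ccccc3)cc2)oc1=O` differs from compound 1 by methyl in place of hydrogen on a saturated chain carbon bound to a saturated chain carbon and a triple-bonded carbon. Going by the values given here, no measured step touches the chain that carries the nitrile, so nothing among the measured compounds bears directly on this change. Without such a precedent, only a small step is expected, with a 1.8-fold higher number from compound 1 to compound 3 (0.26 log units; within the scatter) near the scatter. Compound 3 is therefore estimated at 4 nM in this assay, in a range from 1.5 nM to 15 nM.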

Compound 3, half-maximal inhibitory concentration: 2400 nM
For compound 3 the middle estimate is 600-fold (2.78 log units) below the measured one; measured number outside the range, above it.
By their numbers in this assay, from the lowest: compound 1; then compound 2; then compound 3.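

Methyl in place of hydrogen on this saturated chain carbon, which turns 2-cyanoethyl into 2-cyanopropyl, gives a 1100-fold higher number from compound 1 to compound 3 (3.04 log units; beyond the scatter) in this assay. For the compounds shown here, that step is far larger than the only step on the aromatic ring, a 5.5-fold higher number from compound 1 to compound 2 (0.74 log units; beyond the scatter), so a single added carbon on the chain that carries the nitrile can matter more here than chloro on the ring. Nothing shown gives a reason for the size of this step. Going by these compounds, whether fluorine or hydroxyl on the same carbon would act like methyl stays open, as does the effect of a longer chain or of an amide in place of the nitrile.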